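Working notes on lipophilicity across four related compounds

A few compounds are considered here, and "the series" means these few. Any claim that something is new, unique, unknown or untested is made for them only; others in the source may bear on it.

Measured in a physicochemical assay for lipophilicity, measured as octanol-water partition; a higher number here means a more lipophilic compound, a lower number a more polar compound:
compound 1, `CCO/N=C/Nc1cc(Cl)c(S(=O)(=O)CC)c(Cl)c1`, gives 2.8
compound 2, `C#CCOc1c(Cl)cc(N/C=N/OCC)cc1Cl`, gives 3.6
compound 3, `C#CCc1c(Cl)cc(N/C=N/OCCC)cc1Cl`, gives 4

Compound 3 stands highest of the three numbers; compound 2 is nearest and lies below it beyond the scatter, compound 1 is furthest and lowest. For the measured compounds named here, the single step with one change, a number 0.80 log units higher from compound 1 to compound 2 (beyond the scatter), concerns a group on an aromatic carbon and so does not bear directly on the change now in view. Compounds 2 and 3 differ in two places; their two values only show that compound 3 lies higher.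

Compound 4 is `C#CCc1c(Cl)cc(N/C=N/OC/C=C/Cl)cc1Cl`. It differs from compound 3 as follows: 2-chloroethenyl in place of ethyl on a saturated chain carbon bound to an oxygen

Going by the values given here, no measured step covers this kind of change. The entering group brings one more heavy atom, a chlorine and a double bond, with no donors or acceptors, so an upward step of a number 0.50 log units higher from compound 3 to compound 4 (beyond the scatter) is expected in this assay, beyond the scatter. For compound 4 the estimate is 4.5, in the range 4 to 5.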

Compound 4, partition coefficient: 3.9
Compound 4: the middle estimate sits 0.60 log units above what was measured; the measured number lies below the stated range.
By their numbers in this assay, from the lowest: compound 1; then compounds 2, 4 and 3 (each within the scatter of the next, the first and the last beyond it).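

In this assay, 2-chloroethenyl in place of ethyl on a saturated chain carbon bound to an oxygen gives a number 0.10 log units lower from compound 3 to compound 4 (within the scatter), so the values of this pair cannot be told apart. For the compounds shown here, this is the first reading at this place in the chain, and the earlier step, on an aromatic carbon, had been beyond the scatter; here, the entering chlorine and double bond bring no step that can be separated from the scatter. Nothing at hand accounts for this result.

Going by these compounds alone, the single pair does not separate the chlorine from the double bond, and it says nothing about other cores. As far as these compounds go, how a longer chain, a terminal hydroxyl or an amine at the same place would read in this assay remains open.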